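Replacing the fluorophenyl anilide with a dimethylaminoethyl amide

The source may hold more compounds than are shown below. What is called first, only, known or untested is meant among the compounds shown, and "the series" means these compounds.

Three measured compounds share one core and differ only at the carbonyl carbon at the far end of the chain. Compound 1 `O=C(O)CCC(=O)OCCCCCCSc1ccc([N+](=O)[O-])c2nonc12` keeps a free hydroxy there, and in an ADME assay on HUVEC cells (Homo sapiens) for cytotoxicity, read by MTT assay, with a stated time of 72 h (on this read-out higher numbers stand for weaker inhibition and lower numbers for stronger inhibition), compound 1 gives 740 nM. Compound 2 `O=C(CCC(=O)OCCCCCCSc1ccc([N+](=O)[O-])c2nonc12)Nc1ccc(F)cc1` carries a (4-fluorophenyl)amino group instead, and in this assay compound 2 gives 1740 nM, the highest of the three numbers, though its gap to compound 3 is within the scatter. Compound 3 `COc1ccc(NC(=O)CCC(=O)OCCCCCCSc2ccc([N+](=O)[O-])c3nonc23)cc1OC` bears a (3,4-dimethoxyphenyl)amino group, and in this assay compound 3 gives 870 nM.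

Among the measured compounds shown here, the steps so far are a 2.4-fold higher number from compound 1 to compound 2 (0.37 log units; beyond the scatter), a 1.2-fold higher number from compound 1 to compound 3 (0.07 log units; within the scatter) and a 2.0-fold lower number from compound 2 to compound 3 (0.30 log units; within the scatter). Compound 4 `CN(C)CCNC(=O)CCC(=O)OCCCCCCSc1ccc([N+](=O)[O-])c2nonc12` differs from compound 2 by 2-(dimethylamino)ethyl in place of 4-fluorophenyl on an amide-type nitrogen. For the measured compounds named here, no measured step puts a chain of this kind on the amide-type nitrogen, so the only guidance is that changes at this end have moved this assay by at most a modest amount. Compound 4 is therefore expected near the middle of the measured range, at 1200 nM, between 500 nM and 3000 nM. The expected step is a 1.5-fold lower number from compound 2 to compound 4 (0.16 log units; within the scatter).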

Compound 4, half-maximal inhibitory concentration: 2160 nM
The estimate for compound 4 lay 1.8-fold (0.26 log units) below the measured number; low and high end bracket the measured number.
By their numbers in this assay, from the lowest: compounds 1, 3, 2 and 4 (each within the scatter of the next, the first and the last beyond it).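

Among the compounds shown here, putting 2-(dimethylamino)ethyl in place of 4-fluorophenyl on the amide-type nitrogen, the first group without a ring at this place, gives in this assay a 1.2-fold higher number from compound 2 to compound 4 (0.09 log units; within the scatter), so the aromatic ring of compound 2 can be exchanged for this amine chain with no change that can be told from the scatter. The same exchange measured against the dimethoxy anilide gives a 2.5-fold higher number from compound 3 to compound 4 (0.39 log units; beyond the scatter), and the amide measured against the free acid gives a 2.9-fold higher number from compound 1 to compound 4 (0.47 log units; beyond the scatter), so of the three amides only compound 4 stands beyond the scatter from both compound 1 and compound 3. Nothing available explains these steps.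

As far as these compounds go, what remains open is whether the amine matters at all: a plain alkyl chain without the amine would separate losing the ring from adding the nitrogen. A longer chain ending in the same dimethylamino group, or a morpholine, is equally untested in the compounds shown.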